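Swapping the amide group of compound 3

The source may hold more compounds than are shown below. What is called first, only, known or untested is meant among the compounds shown, and "the series" means these compounds.

Of the compounds shown here, three sharing closely related cores have been measured in a functional assay on L6 cells (Rattus norvegicus) for inhibition; a lower number here means a stronger inhibitor, a higher number a weaker inhibitor: compound 1 `CC(C)c1c(C(=O)N(C)Cc2cccc(F)c2)nn(-c2ccc(F)cc2)c1CC[C@@H](O)C[C@@H](O)CC(=O)O` gives 1900 nM, compound 2 `Cc1ccccc1CNC(=O)c1nn(-c2ccc(F)cc2)c(OC[C@@H](O)C[C@@H](O)CC(=O)O)c1C(C)C` gives 2850 nM and compound 3 `COCc1cccc(CNC(=O)c2nn(-c3ccc(F)cc3)c(OC[C@@H](O)C[C@@H](O)CC(=O)O)c2C(C)C)c1` gives 3600 nM. Compound 3 lies within the usual scatter of both of the others, so these data do not set it apart from either one.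

Compound 4 `CC(C)c1c(C(=O)N(C)Cc2cccc(F)c2)nn(-c2ccc(F)cc2)c1OC[C@@H](O)C[C@@H](O)CC(=O)O` keeps the core of compound 3 and changes one group: (3-fluorobenzyl)(methyl)amino in place of (3-(methoxymethyl)benzyl)amino on a carbonyl carbon. In words, (3-fluorobenzyl)(methyl)amino replaces (3-(methoxymethyl)benzyl)amino on a carbonyl carbon.

For the measured compounds named here, no measured step isolates this swap. The nearest evidence is a 1.3-fold higher number from compound 2 to compound 3 (0.10 log units; within the scatter), a change of the aromatic group in the same region that stays within the scatter. Compound 1 also carries (3-fluorobenzyl)(methyl)amino on its carbonyl carbon, although its chain differs from that of compound 4, and compound 1 gives 1900 nM. Neither observation points to a large shift, though one small step is thin support.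

The expected change is a 1.4-fold lower number from compound 3 to compound 4 (0.16 log units; within the scatter), which means no shift beyond the scatter is anticipated. For compound 4 the estimated value is 2500 nM, with an expected range from 900 nM to 7000 nM.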

Compound 4, half-maximal inhibitory concentration: 2470 nM
For compound 4 the middle estimate is 1.0-fold (0.01 log units) above the measured one; the range from low to high includes it.
By their numbers in this assay, from the lowest: compounds 1, 4, 2 and 3 (each within the scatter of the next).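

In this assay, replacing (3-(methoxymethyl)benzyl)amino with (3-fluorobenzyl)(methyl)amino on the carbonyl carbon removes the amide hydrogen, adds a methyl group on the nitrogen and changes the ring substituent, yet the result stays within the scatter (a 1.5-fold lower number from compound 3 to compound 4 (0.16 log units; within the scatter)). The same holds when the group replaced is (2-methylbenzyl)amino (a 1.2-fold lower number from compound 2 to compound 4 (0.06 log units; within the scatter)), so this position has now tolerated three different amide groups without a shift that can be told from the scatter. For the compounds shown here, compound 4 also gives the first direct reading of the chain change, (5-carboxy-2,4-dihydroxypentyl)oxy in place of 6-carboxy-3,5-dihydroxyhexyl on an aromatic carbon, which likewise stays within the scatter (a 1.3-fold higher number from compound 1 to compound 4 (0.11 log units; within the scatter)), and no supporting information is available to explain any of these results.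

Because the three amide groups combine several changes, these compounds leave open what the methyl group on the nitrogen or the fluorine contributes alone. They also leave open whether a larger change at this carbonyl carbon, such as a piperidine amide or a benzyl ring bearing a nitrile, would move the number beyond the scatter.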